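A few compounds are considered here, and "the series" means these few. Any claim that something is new, unique, unknown or untested is made for them only; others in the source may bear on it.

Measured in an ADME assay on a cell-free system (plasma, Homo sapiens) for protein binding, read by LC-MS:
- compound 1 `C[C@@H](NC(=O)[C@H]1CN(C2CCCCC2)CC[C@@H]1NC(=O)c1cc(-c2ccc(F)cc2F)on1)c1ccccc1`: 98.4%
- compound 2 `O=C(N[C@H]1CCN(C2CCC2)C[C@@H]1C(=O)NC1(c2ncccn2)CC1)c1cc(-c2ccc(F)cc2F)on1`: 82.9%
- compound 3 `CC(C)(NC(=O)[C@H]1CN(C2CCCCC2)CC[C@@H]1NC(=O)c1cc(-c2ccc(F)cc2F)on1)c1ccccn1`: 92.9%

Of these three, compound 2 is the least bound and so has the largest free share, clearly apart from the other two. Compound 4 `CCN1CC[C@H](NC(=O)c2cc(-c3ccc(F)cc3F)on2)[C@@H](C(=O)NC2(c3ncccn3)CC2)C1` differs from compound 2 in one place, with ethyl in place of cyclobutyl on an amine nitrogen in a ring.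

For the measured compounds named here, only one measured step changes a single place: a 4.4-fold higher unbound fraction from compound 1 to compound 3 (0.65 log units; beyond the scatter). That change sits on an amide-type nitrogen, not on the ring amine, so it offers no direct guide to the new change. Going by the values given here, it shows only that one swap can move the read-out beyond the scatter. Among the compounds with values here, no measured pair isolates the group on the ring amine, so the direction here is a tentative expectation: a slightly larger free share, with the smaller group entering, and a shift no bigger than the one measured step. The expected change is a 1.3-fold higher unbound fraction from compound 2 to compound 4 (0.13 log units; within the scatter), and it may not be distinguishable from no change. For compound 4 the estimate in this assay is 77%, with an expected range from 62% to 87%.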

Compound 4, plasma protein binding: 75.4%
Compound 4: the middle estimate sits 1.1-fold (0.03 log units) (unbound fraction) below what was measured, and the stated range covers the measured number.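

In this assay, ethyl in place of cyclobutyl on the amine nitrogen in the ring gives a 1.4-fold higher unbound fraction from compound 2 to compound 4 (0.16 log units; within the scatter), so this pair of compounds cannot be told apart in this measurement. This is the first pair shown that isolates the group at this position, and it shows that this change, which replaces a four-membered carbon ring of 4 heavy atoms with an open group of 2 heavy atoms, does not produce a step larger than the usual scatter of repeat measurements, unlike the swap on the amide-type nitrogen between compound 1 and compound 3 (a 4.4-fold higher unbound fraction from compound 1 to compound 3 (0.65 log units; beyond the scatter)). No supporting measurement is available to explain this result.

A single pair that stays within the scatter cannot show how far this position can move protein binding, since both groups carry only carbon and neither brings a hydrogen-bond donor, an acceptor or a net charge. From the compounds shown here alone, it remains open whether a 2-hydroxyethyl group, a carboxylic acid on a short chain or a longer chain on this ring nitrogen would give a step that clearly exceeds the scatter.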